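The source may hold more compounds than are shown below. What is called first, only, known or untested is meant among the compounds shown, and "the series" means these compounds.

Measured so far in an ADME assay on MCF7-DOX cells (Homo sapiens) for cytotoxicity, read by MTT assay, with a stated time of 48 h; a higher number here means a weaker inhibitor, a lower number a stronger inhibitor:
- Compound 1 `COc1cc(OC)c(C(=O)/C=C/c2cccc(Cl)c2)c(O)c1CC=C(C)C` gives 59500 nM
- Compound 2 `COc1cc(OC)c(C(=O)/C=C/c2cccc(C(F)(F)F)c2)c(O)c1CC=C(C)C` gives 66600 nM
- Compound 3 `COc1cc(OC)c(C(=O)/C=C/c2ccc(Cl)cc2)c(O)c1CC=C(C)C` gives 43400 nM

Compound 3 does not stand apart from the other two. The steps reaching it are a 1.4-fold lower number from compound 1 to compound 3 (0.14 log units; within the scatter) and a 1.5-fold lower number from compound 2 to compound 3 (0.19 log units; within the scatter) in size, so all three numbers count as level.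

Compound 4 `COc1ccc(/C=C/C(=O)c2c(OC)cc(OC)c(CC=C(C)C)c2O)cc1` differs from compound 3 by a single swap: methoxy in place of chloro on an aromatic carbon, para to a large group (methoxy in place of chloro on an aromatic carbon). Among the measured compounds shown here, no measured step makes this exact swap, so the evidence is indirect. The closest cases are trifluoromethyl in place of chloro (a 1.1-fold higher number from compound 1 to compound 2 (0.05 log units; within the scatter)) and 4-chlorophenyl in place of 3-chlorophenyl (a 1.4-fold lower number from compound 1 to compound 3 (0.14 log units; within the scatter)), and neither leaves the scatter. On that basis, no step beyond the scatter is expected, in either direction.

In this assay the expected step is a 1.2-fold higher number from compound 3 to compound 4 (0.06 log units; within the scatter) and no larger.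

Compound 4 is estimated at 50000 nM in the middle, with an expected range from 25000 nM to 95000 nM around it.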

Compound 4, half-maximal inhibitory concentration: 46900 nM
Estimate against measurement, compound 4: 1.1-fold (0.03 log units) above, and the stated range covers the measured number.
By their numbers in this assay, from the lowest: compounds 3, 4, 1 and 2 (each within the scatter of the next).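

In this assay, putting methoxy (1 hydrogen-bond acceptor) in place of chloro (0 hydrogen-bond acceptors) on this aromatic carbon, para to a large group, gives a 1.1-fold higher number from compound 3 to compound 4 (0.03 log units; within the scatter) and so leaves the number level. The comparisons that change the whole aromatic group agree: 4-methoxyphenyl in place of 3-(trifluoromethyl)phenyl gives a 1.4-fold lower number from compound 2 to compound 4 (0.15 log units; within the scatter) and 4-methoxyphenyl in place of 3-chlorophenyl gives a 1.3-fold lower number from compound 1 to compound 4 (0.10 log units; within the scatter) with neither step leaving the scatter. Among the compounds shown here, all four compounds therefore remain level, and the added hydrogen-bond acceptor brings no step that can be read in this assay.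

From the compounds shown here alone, whether an amine, a carboxylic acid or a longer chain on this same aromatic carbon would move the number beyond the scatter remains open. Nothing available explains why these numbers stay level.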